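Aryl swap on the shared core: compound 3 to compound 4

A few compounds are considered here, and "the series" means these few. Any claim that something is new, unique, unknown or untested is made for them only; others in the source may bear on it.

Three compounds of the series carry a different aryl group on the same aromatic carbon of the shared core. Compound 1 `Cc1nc2c3ccccc3ccc2c2nc3c(ccc4ccccc43)c(-c3cccnc3)c12` gives 63.6 ug/mL in a functional assay, read by spectrophotometry, with a stated time of 15 min; on this read-out higher numbers stand for weaker inhibition and lower numbers for stronger inhibition. Compound 2 `COc1ccc(-c2c3ccc4ccccc4c3nc3c2c(C)nc2c4ccccc4ccc32)cc1` gives 82.3 ug/mL in this assay. Compound 3 `Cc1nc2c3ccccc3ccc2c2nc3c(ccc4ccccc43)c(-c3cc([N+](=O)[O-])ccc3N)c12` gives 43.3 ug/mL in this assay. Compound 3 holds the lowest of the three numbers, but the steps of a 1.5-fold lower number from compound 1 to compound 3 (0.17 log units; within the scatter) and a 1.9-fold lower number from compound 2 to compound 3 (0.28 log units; within the scatter) both sit within the scatter, as does a 1.3-fold higher number from compound 1 to compound 2 (0.11 log units; within the scatter), so no ordering among the three can be read from the numbers.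

Compound 4 `Cc1nc2c3ccccc3ccc2c2nc3c(ccc4ccccc43)c(-c3ccccc3Cl)c12` differs from compound 3 by 2-chlorophenyl in place of 2-amino-5-nitrophenyl on an aromatic carbon. The three measured steps all exchange the aryl group at this same position and all stay within the scatter, so the aryl group has so far made no difference that the assay resolves. The step from compound 3 to compound 4 is expected to behave in the same way, with a 1.4-fold higher number from compound 3 to compound 4 (0.14 log units; within the scatter) as the estimated change, not beyond the scatter. Compound 4 is therefore estimated to give 60 ug/mL in this assay, with an expected range from 30 ug/mL to 120 ug/mL.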

Compound 4, half-maximal inhibitory concentration: 74.6 ug/mL
Compound 4: middle estimate off by 1.2-fold (0.09 log units), on the low side, and the stated range covers the measured number.
By their numbers in this assay, from the lowest: compounds 3, 1, 4 and 2 (each within the scatter of the next).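

Exchanging 2-amino-5-nitrophenyl, which carries a hydrogen-bond donor and acceptors, for 2-chlorophenyl, which carries neither, still gives no difference that this assay resolves: a 1.7-fold higher number from compound 3 to compound 4 (0.24 log units; within the scatter). The chlorine-bearing ring also stays level with the other two aryl groups, with a 1.1-fold lower number from compound 2 to compound 4 (0.04 log units; within the scatter) and a 1.2-fold higher number from compound 1 to compound 4 (0.07 log units; within the scatter), so all four aryl groups on this aromatic carbon opposite the ring nitrogen lie within the scatter of one another, and the series has no exception so far. No independent measurement is available to account for this insensitivity.

As far as these compounds go, all four compounds place a six-membered aromatic ring on this carbon, so the response to a non-aromatic group, such as a morpholine, a longer alkyl chain or a carboxylic acid, remains open. From the compounds shown here alone, the rest of the shared core, including its methyl group, is identical across the four compounds, so whether a change there would produce a step beyond the scatter also remains open.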